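A Chromanone Side Chain Swapped for an Epoxide

The source may report more compounds than this note shows. Statements on the series, on what has been measured and on what is new or still open speak of the compounds shown alone.

Of the compounds shown here, three sharing one core have been measured in a functional assay on A549 cells (Homo sapiens) for inhibition, read by sulforhodamine B assay, with a stated time of 48 h, tested at 50 uM; a lower number here means less inhibition of growth, a higher number more inhibition of growth at the concentration tested. Compound 1 `COc1cc2c(cc1CC=C(C)C)/C(=N/NC(N)=O)C[C@@H](c1ccc(O)cc1)O2` gives 77%, compound 2 `COc1cc2c(cc1CC=C(C)C)C(=O)C[C@@H](c1ccc(Oc3ccccc3)cc1)O2` gives 46%, and compound 3 `COc1cc2c(cc1CCC(C)C)C(=O)C[C@@H](c1ccc(O)cc1)O2` gives 75%. Compound 3 thus stands second highest of the three numbers: its nearest neighbour is compound 1, whose number lies within the usual scatter of that of compound 3, while compound 2 lies lower by a gap beyond the scatter.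

The unmeasured compound 4 `COc1cc2c(cc1CC1OC1(C)C)C(=O)C[C@@H](c1ccc(O)cc1)O2` differs from compound 3 in a single place: 3,3-dimethyloxiran-2-yl in place of isobutyl on a saturated chain carbon bound to an aromatic carbon. The chain keeps its four carbons but is closed into a small ring carrying one oxygen.

Among the measured compounds shown here, no step between two measured compounds that differ only there is available, so the expectation must rest on the whole set. Compound 1, with a different chain on the same carbon, gives 77% in this assay, a number within the scatter of compound 3, which suggests that this chain is not what sets the level. The expected step in this assay from compound 3 to compound 4 is therefore small, a number 1 percentage points lower from compound 3 to compound 4 (within the scatter), and not beyond the scatter in either direction. Compound 4 is estimated to give 74%, within a range from 55% to 90%.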

Compound 4, percent growth inhibition at one concentration: 79%
Compound 4: middle estimate off by 5 percentage points, on the low side; measured number inside the range.
By their numbers in this assay, from the lowest: compound 2; then compounds 3, 1 and 4 (each within the scatter of the next).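

In this assay, among the compounds shown here, the swap of isobutyl for 3,3-dimethyloxiran-2-yl on a saturated chain carbon bound to an aromatic carbon reads as a number 4 percentage points higher from compound 3 to compound 4 (within the scatter) and gives the first direct step at this position, since the earlier compounds offered no pair differing only there. It shows that this place accepts a group with one more heavy atom, a three-membered ring and a hydrogen-bond acceptor while the number stays within the scatter of that of the isobutyl compound, so neither the open saturated chain nor the absence of a ring oxygen is needed to hold the level at the concentration tested. No measurement shown here offers an explanation for this result.

On these data alone, what remains open is whether a primary amine, a carboxylic acid or a longer chain such as n-octyl on the same carbon would also stay within the scatter of compound 3, or would mark a limit to what this position accepts. A reading at a single concentration also leaves open whether compound 3 and compound 4 would still lie within the scatter of each other at lower concentrations.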